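Compound 3 to compound 4: an aryl change at the limit

A few compounds are considered here, and "the series" means these few. Any claim that something is new, unique, unknown or untested is made for them only; others in the source may bear on it.

In a functional assay on HUVEC cells (Homo sapiens) (on this read-out lower numbers stand for an effect already at smaller amounts and higher numbers for an effect only at larger amounts of compound), compound 1 `COC1=C(C)C(=O)/C(=C(O)/C=C/c2ccc(Br)cc2)C(=O)C1(C)C` gives < 4 ug/mL, a limit. Compound 2 `COC1=C(C)C(=O)/C(=C(O)/C=C/c2ccc(F)cc2)C(=O)C1(C)C` gives < 4 ug/mL, also a limit. Compound 3 `COC1=C(C)C(=O)/C(=C(O)/C=C/c2ccccc2C)C(=O)C1(C)C` gives < 4 ug/mL, again a limit and not a number. Within the data shown here, the series so far stands at one limit: the limit of < 4 ug/mL in this assay, at which 3 of the 3 values shown sit.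

Compound 4 `CCc1ccc(/C=C/C(O)=C2/C(=O)C(C)=C(OC)C(C)(C)C2=O)cc1` differs from compound 3 at a single place: 4-ethylphenyl in place of 2-methylphenyl on a double-bonded chain carbon bound to a double-bonded chain carbon. The measured changes at that place are a step that the two limits leave unreadable from compound 1 to compound 3 and a step that the two limits leave unreadable from compound 2 to compound 3. Neither gives a size to carry over, and neither gives a direction. In this assay no step beyond the scatter is expected, and the estimated step is a step that the limit leaves unreadable from compound 3 to compound 4. The expected value for compound 4 is 2 ug/mL, with an estimated range of 0.6 ug/mL to 5 ug/mL.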

Compound 4, concentration for half-maximal effect: < 4 ug/mL
Compound 4 ended at the assay's limit; the forecaster's own chance of this, stated with the estimate: 70%; the middle value is on the limit's open side.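

In this assay compound 4 gives < 4 ug/mL, a limit and not a number. Its steps to compound 1, compound 2 and compound 3 cannot be read, and the series stands at one value: the limit of < 4 ug/mL in this assay, at which 4 of the 4 values shown sit. The compounds shown leave open how these four actual potencies compare, and whether any of the aryl groups matters in this read-out.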